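Drawn Geometry Flipped: From Compound 2 to Compound 3

The source may report more compounds than this note shows. Statements on the series, on what has been measured and on what is new or still open speak of the compounds shown alone.

Compound 2 `C=CCNC(=S)N/N=C1/CCCc2cccnc21` was tested in a toxicity assay on the whole organism (P388 cells, strain CDF1) for cytotoxicity, with Mus musculus as the target, with stated times of 6 days and 24 h, at a dose of 2.5 mg/kg (a lower number here means a stronger effect, a higher number a weaker effect of the compound at the dose given), where compound 2 gives 4.6%. Within the data shown here, that is the higher of the two values measured so far; compound 1 `CNC(=S)N/N=C1\CCCc2cccnc21` gives -9.3% in this assay, a number lower than that of compound 2 by more than the usual scatter.

Compound 3 `C=CCNC(=S)N/N=C1\CCCc2cccnc21` has not yet been measured. the two compounds have the same atoms and bonds and differ only in configuration as drawn: 1 of 1 stereo elements differ; a double bond is drawn Z in compound 2 and E in compound 3 The atoms and bonds are unchanged. No step beyond the scatter is expected in this assay. Compound 3 is therefore expected to give 2% in this assay, between -12% and 16%, and the expected step of a number 2.6 percentage points lower from compound 2 to compound 3 (within the scatter) should stay within the scatter.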

Compound 3, a percentage reported as activity, at one dose (the size of the read-out at that dose, not a potency): 0.7%
Beside the measured number, compound 3's estimate is 1.3 percentage points above it; low and high end bracket the measured number.
By their numbers in this assay, from the lowest: compounds 1, 3 and 2 (each within the scatter of the next, the first and the last beyond it).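

In this assay, the change of drawn geometry alone gives a number 3.9 percentage points lower from compound 2 to compound 3 (within the scatter), so this double bond shows no step beyond the scatter, and the comparison isolates that one feature: the fact that compounds 2 and 3 differ only in the configuration as drawn At the chain end, with the drawn geometry held the same, vinyl in place of hydrogen on a saturated chain carbon bound to an amide-type nitrogen gives a number 10 percentage points higher from compound 1 to compound 3 (within the scatter), which is also no step beyond the scatter. The compounds shown leave open whether a longer chain, an amine or a carboxylic acid at that chain end would move the number beyond the scatter. From the compounds shown here alone, whether the two geometries also stay within the scatter of each other at other doses remains open too.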